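Epimer at the lactone ring carbon in a sesquiterpene tetronic acid

The source may report more compounds than this note shows. Statements on the series, on what has been measured and on what is new or still open speak of the compounds shown alone.

Measured so far:
compound 1, `CC1=C(O)[C@@H](C/C(C)=C\CC[C@H](C)/C=C/C=C(\C)CCCc2ccoc2)OC1=O`, 9.8 ug/mL
compound 2, `CC1=C(O)[C@H](C/C(C)=C\CC[C@H](C)/C=C/C=C(\C)CCCC2=CCN(CCC(C)C)C2=O)OC1=O`, 5.5 ug/mL

In a functional assay on XF498 cells (Homo sapiens) for cytotoxicity (a lower number here means that less compound is needed, a higher number that more compound is needed for the effect), compound 2 gives the lowest of the two numbers recorded; its nearest neighbour is compound 1, whose value sits higher by a margin that lies within the scatter of this assay, so the two cannot be ranked against each other. Compound 3, `CC1=C(O)[C@@H](C/C(C)=C\CC[C@H](C)/C=C/C=C(\C)CCCC2=CCN(CCC(C)C)C2=O)OC1=O`, has not yet been measured in this assay. It differs from compound 2 only as follows: the two compounds have the same atoms and bonds and differ only in configuration as drawn: 1 of 5 stereo elements differ; a stereocentre at a saturated ring carbon is drawn S in compound 2 and R in compound 3. Among the measured compounds shown here, no step between two measured compounds is available to calibrate such an inversion, and nothing among the two recorded numbers points to a direction. The estimate for compound 3 is therefore built on the value of compound 2 and assumes that the step from compound 2 to compound 3, a 1.2-fold higher number from compound 2 to compound 3 (0.07 log units; within the scatter), stays within the scatter, although a larger shift in either direction cannot be excluded. Compound 3 is expected to give about 6.5 ug/mL, with a range from 3 ug/mL to 14 ug/mL.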

Compound 3, concentration for half-maximal effect: 3.9 ug/mL
Beside the measured number, compound 3's estimate is 1.7-fold (0.22 log units) above it; low and high end bracket the measured number.
By their numbers in this assay, from the lowest: compounds 3, 2 and 1 (each within the scatter of the next, the first and the last beyond it).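

In this assay, inverting the stereocentre at the saturated ring carbon gives a 1.4-fold lower number from compound 2 to compound 3 (0.15 log units; within the scatter), so no preference for either configuration can be read at this position. With the ring-carbon configuration held the same, the group of 11 heavy atoms with its five-membered non-aromatic ring, in place of the group of 5 heavy atoms with its five-membered aromatic ring, gives a 2.5-fold lower number from compound 1 to compound 3 (0.40 log units; beyond the scatter), a modest step and the only one here beyond the scatter. The reading at the stereocentre rests on a pair with nothing else changed: the fact that compounds 2 and 3 differ only in the configuration as drawn

As far as these compounds go, whether the inversion would read the same with the five-membered aromatic ring group in place remains open, as does which part of the larger group carries the step. How a carboxylic acid, an amine or a longer chain at that chain end would compare is also unknown.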